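This account rests on a few compounds, and the source may have more. Where it says the series, first, only, none or still open, it means among the compounds named here.

Measured so far in an ADME assay on MT4 cells (Homo sapiens) for cytotoxicity, read by MTT assay, with a stated time of 5 days; on this read-out higher numbers stand for lower toxicity in this test and lower numbers for higher toxicity in this test:

compound 1 `Cc1cc(C#N)cc(C)c1Oc1cc(Nc2ccc(C#N)cc2)[nH]c(=O)c1Br`: > 287000 nM
compound 2 `Cc1cc(C#N)cc(C)c1Oc1cc(Nc2ccc(C#N)cc2)[nH]c(=O)c1`: 25000 nM
compound 3 `Cc1cc(C#N)cc(C)c1Oc1cc(Nc2ccc(C#N)cc2)[nH]c(=O)c1Cl`: > 319000 nM

Compound 3 stands at the edge of what this assay reports: its reading is a limit, not a number (the limit of > 319000 nM in this assay, at which 1 of the 3 values shown sits). Compound 2 is the only one of the three with a number. The reading for compound 1 is also a limit (the limit of > 287000 nM in this assay, at which 1 of the 3 values shown sits). Between compound 2 and compound 3 the halogen step is large, an at least 12-fold higher number from compound 2 to compound 3 (1.10 log units; beyond the scatter), and the matching step in the other direction, an at least 11-fold lower number from compound 1 to compound 2 (1.05 log units; beyond the scatter), is of the same order. The exchange of one halogen for another, a step that the two limits leave unreadable from compound 1 to compound 3, cannot be read because both readings are limits the limit of > 287000 nM in this assay, at which 1 of the 3 values shown sits (the limit of > 319000 nM in this assay, at which 1 of the 3 values shown sits).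

Compound 4 `Cc1cc(C#N)cc(C)c1Oc1cc(Nc2ccc(C#N)cc2)[nH]c(=O)c1I` differs from compound 3 as follows: iodo in place of chloro on an aromatic carbon. The step that bears on it is the bromo-to-chloro exchange on the same carbon, which left the reading at a limit in both cases. On that basis no step beyond the scatter in this assay is expected for compound 4, and the reading is expected again to be a limit rather than a number. The estimate for compound 4 is 320000 nM, with a range of 100000 nM to 1000000 nM, which means an expected step that the limit leaves unreadable from compound 3 to compound 4.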

Compound 4, half-maximal cytotoxic concentration: > 259000 nM
Compound 4: a limit, no number; the forecaster's own chance of this, stated with the estimate: 80%; the middle value is on the limit's open side.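

In this assay compound 4 gives > 259000 nM, which is a limit and not a number. Iodo in place of hydrogen on this aromatic carbon gives an at least 10-fold higher number from compound 2 to compound 4 (1.01 log units; beyond the scatter), so the bromo, chloro and iodo compounds 1, 3 and 4 all read as limits, and compound 2, with hydrogen at this carbon, is the only one of the series with a number. The steps from iodo to chloro and from iodo to bromo cannot be read, because the readings on both sides of each step are limits: the limit of > 259000 nM in this assay, at which 1 of the 4 values shown sits.

The compounds shown leave open how the three halogens rank against one another on this read-out, and the true readings of compounds 1, 3 and 4 stay unknown. Also open, from the compounds shown here alone, is whether a group other than a halogen on this carbon, such as methyl, methoxy or an amine, would read like compound 2 or like the halogen compounds.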